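Swapping the aryl for a cyclohexyl on the amine side chain

The source may hold more compounds than are shown below. What is called first, only, known or untested is meant among the compounds shown, and "the series" means these compounds.

Compound 1: `CCc1cc(Nc2nc(N[C@@H](C)c3ccc(F)cc3)nc3cccc(F)c23)n[nH]1` gives 41 nM
Compound 2: `CCc1cc(Nc2nc(N[C@H](C)c3ccc(F)cc3)nc3ccccc23)n[nH]1` gives 1400 nM

Of the compounds shown here, two have been tested in an assay on isolated protein for inhibition of G protein-coupled receptor kinase 6 (Homo sapiens), read by scintillation counting, radiometric assay and 33P incorporation, with a stated time of 80 min, in the presence of a further agent that is not named here; a lower number here means a stronger inhibitor, a higher number a weaker inhibitor. Compound 1 gives 41 nM in this assay. Compound 2 is built on the shared core without the ring fluorine that compound 1 carries. In this assay compound 2 gives 1400 nM, the highest of the two numbers, and its gap from compound 1 goes well beyond the usual scatter. The two compounds differ in more than one place, so the numbers alone are what is known of them.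

Compound 3, `CCc1cc(Nc2nc(N[C@@H](C)C3CCCCC3)nc3ccccc23)n[nH]1`, is the next compound to be measured. It differs from compound 2 in one place: 1-cyclohexylethyl in place of 1-(4-fluorophenyl)ethyl on a nitrogen on an aromatic ring. Going by the values given here, no measured pair shows this change, so the expected step from compound 2 to compound 3 rests on judgement rather than precedent. A step of modest size in either direction, or none beyond the scatter, is expected, with a slight lean toward a weaker inhibitor, giving an expected step of a 1.3-fold higher number from compound 2 to compound 3 (0.11 log units; within the scatter). Compound 3 is estimated at 1800 nM, with a range from 400 nM to 8000 nM.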

Compound 3, half-maximal inhibitory concentration: 960 nM
The estimate for compound 3 lay 1.9-fold (0.27 log units) above the measured number; the measured number falls inside the stated range.
By their numbers in this assay, from the lowest: compound 1; then compounds 3 and 2 (each within the scatter of the next).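

In this assay the side chain on a nitrogen on an aromatic ring went from 1-(4-fluorophenyl)ethyl to 1-cyclohexylethyl with a 1.5-fold lower number from compound 2 to compound 3 (0.16 log units; within the scatter) as the whole outcome, so on this core the read-out does not tell the two side chains apart. An aromatic ring of carbon only is therefore not required at this position to keep the number at the level of compound 2, and a non-aromatic ring of carbon only serves equally well in that pair. The swap takes away the aromatic ring and the fluorine together, so this single pair cannot separate one from the other, and no measurement at hand explains why the two side chains read alike.

On these data alone, it remains open whether a plain 1-phenylethyl group, an open chain such as 1-methylbutyl, or a piperidine ring would read the same on that nitrogen. As far as these compounds go, it is equally open whether the swap to 1-cyclohexylethyl would be as quiet on the core of compound 1, which carries the ring fluorine that compound 2 and compound 3 lack.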